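The compounds below may be only part of what the source reports. "The series", "measured", "known", "first", "only" and "open" are said of these compounds alone.

In an ADME assay on L6 cells (Rattus norvegicus) for cytotoxicity, with a stated time of 72 h (a higher number here means a weaker inhibitor, a lower number a stronger inhibitor), compound 2 `CN(C)C12CC(OC(=O)/C=C/c3ccccc3)C(C(c3ccccc3)C1)C(c1ccccc1)C2` gives 3820 nM and compound 3 `O=C(/C=C/c1ccccc1)OC1CC2(N3CCCC3)CC(c3ccccc3)C1C(c1ccccc1)C2` gives 3500 nM, so the two stand level, with a 1.1-fold lower number from compound 2 to compound 3 (0.04 log units; within the scatter). Compound 1 `CC(=O)OC1CC2(N(C)C)CC(c3ccccc3)C1C(c1ccccc1)C2` is recorded as "not determined" (no result reported), which leaves no number for it. Compound 4 `CN(C)C12CC(O)C(C(c3ccccc3)C1)C(c1ccccc1)C2` differs from compound 2 by hydrogen in place of (2-phenylethenyl)carbonyl on an oxygen on a saturated carbon. For the measured compounds named here, the one measured step puts pyrrolidin-1-yl in place of dimethylamino and keeps the (2-phenylethenyl)carbonyl group, so it gives no measure of this change. Going by the values given here, no measured compound carries the hydroxy group, and the direction and size expected in this assay are a judgement with wide uncertainty. The estimate is a 6.5-fold higher number from compound 2 to compound 4 (0.82 log units; beyond the scatter). Compound 4 is expected at 25000 nM, with an estimated range of 7000 nM to 90000 nM.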

Compound 4, half-maximal inhibitory concentration: 133000 nM
Beside the measured number, compound 4's estimate is 5.3-fold (0.73 log units) below it; the measured number lies above the stated range.
By their numbers in this assay, from the lowest: compounds 3 and 2 (each within the scatter of the next); then compound 4.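

In this assay, the oxygen on the saturated carbon proves far more sensitive than the amine: ((2-phenylethenyl)carbonyl)oxy to hydroxy gives a 35-fold higher number from compound 2 to compound 4 (1.54 log units; beyond the scatter), whereas pyrrolidin-1-yl in place of dimethylamino gave only a 1.1-fold lower number from compound 2 to compound 3 (0.04 log units; within the scatter). This is the only step shown that lies beyond the scatter, so the number depends on what this oxygen carries. Nothing measured here accounts for the size of this step. Going by these compounds, whether a benzoyl or 3-phenylpropanoyl group on this oxygen would keep the number near that of compound 2 remains open. So does whether pyrrolidin-1-yl would behave the same alongside the hydroxy group.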